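The source may report more compounds than this note shows. Statements on the series, on what has been measured and on what is new or still open speak of the compounds shown alone.

Measured compounds in an ADME assay on Karpas-1106P cells (Homo sapiens) for cytotoxicity; on this read-out lower numbers stand for an effect already at smaller amounts and higher numbers for an effect only at larger amounts of compound:

- compound 1, `Cc1ccc(S(=O)(=O)N[C@@H](CC(=O)NC(C)(C)C)C(=O)NCCNC(=O)c2cc(C)ccc2F)cc1`, gives > 11100 nM, which is a limit of the assay and not a number.
- compound 2, `Cc1ccc(S(=O)(=O)N[C@@H](CC(=O)NC(C)(C)C)C(=O)NCCNC(=O)c2cc(Cl)ccn2)cc1`, gives > 11100 nM, again a limit.
- compound 3, `Cc1ccc(S(=O)(=O)N[C@@H](CC(=O)NC(C)(C)C)C(=O)NCCNC(=O)c2cccc(O)c2)cc1`, gives > 11100 nM, also a limit.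

Where compound 3 stands: only a limit is known for it, and the same holds for the two other compounds, as the limit of > 11100 nM in this assay, at which 3 of the 3 values shown sit, shows. The three steps between the measured compounds, a step that the two limits leave unreadable from compound 1 to compound 2, a step that the two limits leave unreadable from compound 1 to compound 3 and a step that the two limits leave unreadable from compound 2 to compound 3, each run between two limits and therefore cannot be read in size or direction.

Compound 4, `COc1cccc(C(=O)NCCNC(=O)[C@H](CC(=O)NC(C)(C)C)NS(=O)(=O)c2ccc(C)cc2)c1`, has not been measured in this assay. It differs from compound 3 by methyl in place of hydrogen on an oxygen on an aromatic ring. For the measured compounds named here, none of the measured steps concerns a change on the oxygen on the aromatic ring, so no step bears directly on this change; what the series shows is only that every variation of the aryl carbonyl so far has stayed at the limit.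

For compound 4 the step that the limit leaves unreadable from compound 3 to compound 4 is expected to be none beyond the scatter. Compound 4 is estimated at 15000 nM, with a range from 7000 nM to 40000 nM, and most likely the assay will again report only a limit.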

Compound 4, half-maximal effective concentration: > 11100 nM
Compound 4: a limit, no number; the forecaster's own chance of this, stated with the estimate: 85%; the middle value is on the limit's open side.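

In this assay compound 4 gives > 11100 nM as a limit and not a number. Its steps to compound 1, compound 2 and compound 3 all run between limits and cannot be read, and the series now stands at a single limit: the limit of > 11100 nM in this assay, at which 4 of the 4 values shown sit.

The compounds shown leave open at what concentration any of the four has an effect, and whether any change on the aryl carbonyl alters it.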